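Lactam ring size on the aryl ether in this series

A few compounds are considered here, and "the series" means these few. Any claim that something is new, unique, unknown or untested is made for them only; others in the source may bear on it.

Going by the values given here, compound 3 `Cc1ccc(Nc2nc(N)nc(COc3cccc(N4CCCC4=O)c3)n2)cc1Cl` is the only member of the set with a numerical result: in an assay on COS-7 cells for agonist activity at Free fatty acid receptor 1 (Homo sapiens), read by scintillation counting and inositol phosphate accumulation, with a stated time of 90 min (a higher number here means that more compound is needed for the effect, a lower number that less compound is needed), compound 3 gives 820 nM. Among the compounds with values here, compound 1 `Cc1cc(=O)oc2cc(OCc3nc(N)nc(Nc4cccc(O)c4)n3)ccc12` has in this assay only the entry "not determined" (no result reported), and compound 2 `Cc1cc(=O)oc2cc(OCc3nc(N)nc(Nc4ccc(O)cc4)n3)ccc12` has only the entry "not determined" (no result reported), so compound 3 stands alone and no step between measured compounds can be computed.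

Compound 4 `Cc1ccc(Nc2nc(N)nc(COc3cccc(N4CCCCC4=O)c3)n2)cc1Cl` is the next entry to be measured. Its difference from compound 3 is 2-oxopiperidin-1-yl in place of 2-oxopyrrolidin-1-yl on an aromatic carbon, in words 2-oxopiperidin-1-yl in place of 2-oxopyrrolidin-1-yl on an aromatic carbon. Within the data shown here, the series holds no measured pair that shows what a ring expansion of this kind does in this assay, so any expectation rests on the single value of compound 3 and on the modest scale of the change. The expected step of a 1.0-fold lower number from compound 3 to compound 4 (0.01 log units; within the scatter) is taken as lying within the usual scatter, with no preferred direction. On that basis compound 4 is expected to give 800 nM, with a range from 300 nM to 2500 nM.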

Compound 4, half-maximal effective concentration: 22400 nM
Compound 4: the middle estimate sits 28-fold (1.45 log units) below what was measured, and the stated range ends below it.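

In this assay, going by these compounds alone, 2-oxopiperidin-1-yl in place of 2-oxopyrrolidin-1-yl gives a 27-fold higher number from compound 3 to compound 4 (1.44 log units; beyond the scatter), the first step that can be read. At this place, on an aromatic carbon meta to a large group, the five-membered and six-membered lactams are therefore not interchangeable, and the five-membered ring carries the lower number of this pair. Nothing at hand accounts for the size of this step.

The compounds shown do not tell whether the number keeps rising with ring size, or how an open-chain acetamide, a morpholine or a carboxylic acid would read at the same place. Going by these compounds, with a single pair, it also remains open whether this lactam change would give a similar step with a different group on the aniline ring.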